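The source may report more compounds than this note shows. Statements on the series, on what has been measured and on what is new or still open speak of the compounds shown alone.

Compound 1 `CC(C)n1ncc2c(C(=O)NCc3cn(-c4ccccc4)nn3)cccc21`: 26000 nM
Compound 2 `CC(C)n1ncc2c(C(=O)NCc3cn(-c4ccc(C(F)(F)F)cc4)nn3)cccc21`: 38600 nM
Compound 3 `CC(C)n1ncc2c(C(=O)NCc3cn(Cc4ccccc4)nn3)cccc21`: 4420 nM

Of the compounds shown here, three have been measured in a functional assay on PC-3 cells (Homo sapiens) for inhibition, read by MTT assay, with a stated time of 72 h; on this read-out higher numbers stand for weaker inhibition and lower numbers for stronger inhibition. Compound 1 gives 26000 nM, compound 2 gives 38600 nM and compound 3 gives 4420 nM. Compound 3 differs from compound 1 in its core: benzyl in place of phenyl on an aromatic nitrogen. That change gives a 5.9-fold lower number from compound 1 to compound 3 (0.77 log units; beyond the scatter), and from compound 2 the step is an 8.7-fold lower number from compound 2 to compound 3 (0.94 log units; beyond the scatter). On the core of compound 1, the change trifluoromethyl in place of hydrogen on an aromatic carbon gives a 1.5-fold higher number from compound 1 to compound 2 (0.17 log units; within the scatter).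

Compound 4 `CC(C)n1ncc2c(C(=O)NCc3cn(Cc4ccc(C(F)(F)F)cc4)nn3)cccc21` has not yet been measured. It differs from compound 3 by trifluoromethyl in place of hydrogen on an aromatic carbon, the same change as from compound 1 to compound 2, made this time on the core of compound 3; the place of the change is described in the same words in both cases. Seen once, this change gave a step within the scatter. On that basis the step from compound 3 to compound 4 is expected to be a 1.2-fold higher number from compound 3 to compound 4 (0.09 log units; within the scatter), close to the earlier one, because a 1.5-fold higher number from compound 1 to compound 2 (0.17 log units; within the scatter) was small. Compound 4 is therefore estimated at 5500 nM, with a likely range from 2500 nM to 13000 nM.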

Compound 4, half-maximal inhibitory concentration: 23900 nM
Compound 4: middle estimate off by 4.3-fold (0.64 log units), on the low side; measured number outside the range, above it.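

In this assay, trifluoromethyl in place of hydrogen gives a 5.4-fold higher number from compound 3 to compound 4 (0.73 log units; beyond the scatter), so on the benzyl-bearing core of compound 3 the change produces a step beyond the scatter. Its size did not carry over from the core of compound 1 to the core of compound 3: the same change on two cores in this assay, a 1.5-fold higher number (0.17 log units; within the scatter) from compound 1 to compound 2 and a 5.4-fold higher number (0.73 log units; beyond the scatter) from compound 3 to compound 4, 3.6-fold (0.56 log units) apart, beyond the scatter of two such steps. This shows that a step seen on one of these cores was a poor guide to the other, but two pairs do not show how the change would behave on any further core, and a shared direction cannot be claimed, as the step from compound 1 to compound 2 lies within the scatter.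

The compounds shown leave open whether another group at the same place on the ring, such as chlorine, a methoxy group or a carboxylic acid, would also differ in size between the two cores. They also leave open what an amine or a longer chain would do in place of the isopropyl group, which stays the same throughout.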